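This account rests on a few compounds, and the source may have more. Where it says the series, first, only, none or still open, it means among the compounds named here.

Working notes on the series. Compound 1 `CC(=O)c1cc(-c2ccccc2)cc2cc(-c3ccccc3)[nH]c12` carries an acetyl group and two phenyl groups on the shared core. In a functional assay on HeLa cells (Homo sapiens) for cytotoxicity, read by MTT assay, with a stated time of 2 days (a higher number here means that more compound is tolerated, a lower number that less compound is tolerated), compound 1 gives > 100000 nM, which is a limit of the assay and not a number. Compound 2 `CC(=O)c1cc(-c2ccccc2)cc2cc(-c3ccc(F)cc3)[nH]c12` differs from compound 1 by fluoro in place of hydrogen on an aromatic carbon. In this assay compound 2 gives > 100000 nM, again a limit of the assay rather than a number. The step that the two limits leave unreadable from compound 1 to compound 2 therefore cannot be read, as compound 1 and compound 2 both sit at the limit of > 100000 nM in this assay, at which 2 of the 3 values shown sit. Compound 3 `CC(=O)c1cc(/C=C/c2ccccc2)cc2cc(-c3ccccc3)[nH]c12` differs from compound 1 by 2-phenylethenyl in place of phenyl on an aromatic carbon. In this assay, for the measured compounds named here, compound 3 gives 30800 nM, the only number among the three values so far. The step of an at least 3.2-fold lower number from compound 1 to compound 3 (0.51 log units; beyond the scatter) shows that compound 3 is tolerated less well than the limit reached by compound 1.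

Compound 4 `CC(=O)c1cc(/C=C/c2ccccc2)cc2cc(-c3ccc(F)cc3)[nH]c12` has not yet been measured. It differs from compound 3 by fluoro in place of hydrogen on an aromatic carbon, the same kind of change as that from compound 1 to compound 2, with the same surroundings of the place; the two cores differ by 2-phenylethenyl in place of phenyl on an aromatic carbon. The earlier step that the two limits leave unreadable from compound 1 to compound 2 gives no readable size for this change. For compound 4 in this assay the step of a 1.0-fold lower number from compound 3 to compound 4 (0.01 log units; within the scatter) is expected to stay within the usual scatter, because the earlier step that the two limits leave unreadable from compound 1 to compound 2 offers no sign of a shift in either direction. Compound 4 is accordingly expected to give about 30000 nM, with a range from 12000 nM to 80000 nM.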

Compound 4, concentration lethal to 50% of the cells: 16100 nM
Estimate against measurement, compound 4: 1.9-fold (0.27 log units) above, and the stated range covers the measured number.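

In this assay the fluoro change on the core of compound 3, phenyl to 4-fluorophenyl, reads as a 1.9-fold lower number from compound 3 to compound 4 (0.28 log units; within the scatter), so on this core it leaves the number within the usual scatter. With 4-fluorophenyl in place, the exchange of phenyl for 2-phenylethenyl reads as an at least 6.2-fold lower number from compound 2 to compound 4 (0.79 log units; beyond the scatter), which points the same way as the exchange without fluoro, though the limits bound both sizes and fix neither: the same change on two cores in this assay, an at least 3.2-fold lower number (0.51 log units; beyond the scatter) from compound 1 to compound 3 and an at least 6.2-fold lower number (0.79 log units; beyond the scatter) from compound 2 to compound 4; the limit leaves it open whether they differ The fluoro step between the two compounds at the limit cannot be read, so the series does not show whether the fluoro change carries from one core to the other, only that it stays within the scatter on the one core where it can be read: the limit of > 100000 nM in this assay, at which 2 of the 4 values shown sit.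

The compounds shown leave open whether the lower number depends on the 2-phenylethenyl group as such or would also appear with a saturated 2-phenylethyl chain or a longer chain. They also leave open how other groups in place of fluoro, such as chloro, methoxy or an amine, or a carboxylic acid in place of the acetyl group, would read in this assay.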